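Toward compound 4: a second fluorine on the phenoxy ring

The compounds below may be only part of what the source reports. "The series", "measured", "known", "first", "only" and "open" are said of these compounds alone.

Compound 1, `Cc1nn(C)c(Oc2ccc(F)cc2)c1/C=N\CCCCCOc1cc2oc(=O)cc(C)c2cc1Cl`, in a functional assay on HepG2 cells (Homo sapiens) for antiproliferative activity, read by MTT assay, with a stated time of 72 h; on this read-out higher numbers stand for weaker inhibition and lower numbers for stronger inhibition: > 25000 nM, a limit of the assay.
Compound 2, `Cc1nn(C)c(Oc2ccc(Cl)cc2)c1/C=N\CCCCCOc1cc2oc(=O)cc(C)c2cc1Cl`, in this assay: 15300 nM.
Compound 3, `Cc1nn(C)c(Oc2cccc(F)c2)c1/C=N\CCCCCCOc1cc2oc(=O)cc(C)c2cc1Cl`, in this assay: > 25000 nM, a limit of the assay.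

Compound 3 stands at the limit of > 25000 nM in this assay, at which 2 of the 3 values shown sit, a limit rather than a number. Compound 4, `Cc1nn(C)c(Oc2ccc(F)cc2F)c1/C=N\CCCCCCOc1cc2oc(=O)cc(C)c2cc1Cl`, differs from it by 2,4-difluorophenyl in place of 3-fluorophenyl on an oxygen on an aromatic ring. Within the data shown here, the only measured step, an at least 1.6-fold lower number from compound 1 to compound 2 (0.21 log units; that floor lies within the scatter), changes a different halogen on that ring and lies within the scatter, so no measured step bears on adding a second fluorine. No step beyond the scatter is expected. Compound 4 is expected to give 25000 nM, within 10000 nM to 60000 nM. The expected step, a number no higher from compound 3 to compound 4 (the limit leaves the size open), stays within the scatter.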

Compound 4, half-maximal inhibitory concentration: > 25000 nM
Compound 4 was reported as a limit (the forecaster's own chance of this, stated with the estimate: 60%); the middle value sits exactly at the limit.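

No step can be read from compound 3 to compound 4, as both are reported only as a limit: the limit of > 25000 nM in this assay, at which 3 of the 4 values shown sit. On these data alone, whether 2,4-difluorophenyl in place of 3-fluorophenyl changes the number in this assay stays open.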